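The compounds below may be only part of what the source reports. "The series", "measured", "known", "first", "only" and "open" are said of these compounds alone.

Measured in a functional assay on SK-BR-3 cells (Homo sapiens) for antiproliferative activity; a lower number here means a stronger inhibitor, a higher number a weaker inhibitor:
Compound 1 `CC(C)=CCc1cc(C(=O)Nc2cc3ccc(OCCCN(C)C(C)(C)C)c(C)c3oc2=O)ccc1O`: 880 nM
Compound 2 `CC(C)=CCc1cc(C(=O)Nc2cc3ccc(OCCCNc4ccccc4)c(C)c3oc2=O)ccc1O`: > 50000 nM (a limit)
Compound 3 `CC(C)=CCc1cc(C(=O)Nc2cc3ccc(OCCCN(C)c4ccccc4)c(C)c3oc2=O)ccc1O`: > 50000 nM (a limit)

Compound 3 stands at the limit of > 50000 nM in this assay, at which 2 of the 3 values shown sit, so it has a limit and no number. Compound 4 `CC(C)=CCc1cc(C(=O)Nc2cc3ccc(OCCCN[C@H](C)c4ccccc4)c(C)c3oc2=O)ccc1O` changes its amine: (1-phenylethyl)amino in place of methyl(phenyl)amino on a saturated chain carbon, three bonds along the chain from an oxygen on an aromatic ring.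

Within the data shown here, two measured steps bear on this change, both large: an at least 56-fold higher number from compound 1 to compound 3 (1.75 log units; beyond the scatter) and an at least 56-fold higher number from compound 1 to compound 2 (1.75 log units; beyond the scatter). The step that the two limits leave unreadable from compound 2 to compound 3 cannot be read. In compound 2 and compound 3 a phenyl sits directly on the amine nitrogen, whereas in compound 4, as in compound 1, it does not. A large move toward stronger inhibition is therefore expected, and the expected step is an at least 20-fold lower number from compound 3 to compound 4 (1.30 log units; beyond the scatter). Compound 4 is estimated at 2500 nM, with an expected range of 500 nM to 25000 nM.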

Compound 4, half-maximal inhibitory concentration: 1000 nM
Compound 4: middle estimate off by 2.5-fold (0.40 log units), on the high side, and the stated range covers the measured number.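

In this assay, moving the phenyl off the amine nitrogen onto a 1-phenylethyl group restores measurable activity, with an at least 50-fold lower number from compound 3 to compound 4 (1.69 log units; beyond the scatter) and an at least 50-fold lower number from compound 2 to compound 4 (1.69 log units; beyond the scatter). Both steps start from limits and not from numbers, the limits of compound 2 and compound 3: the limit of > 50000 nM in this assay, at which 2 of the 4 values shown sit. The phenyl ring itself is therefore not enough to lose activity at this position, since the step to the non-aromatic methyl(tert-butyl)amino group is a 1.1-fold higher number from compound 1 to compound 4 (0.06 log units; within the scatter). The compounds shown leave open whether the mirror-image 1-phenylethyl group would read the same. They also leave open how a benzylamino group, without the branching methyl, would compare.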